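Two Limits and a Larger Group on the Amine Nitrogen

This account rests on a few compounds, and the source may have more. Where it says the series, first, only, none or still open, it means among the compounds named here.

Measured in a functional assay on C8166 cells (Homo sapiens) for antiproliferative activity, read by MTT assay; on this read-out lower numbers stand for higher toxicity in this test and higher numbers for lower toxicity in this test:
Compound 1 `Cc1cc(C)cc(S(=O)(=O)c2c(C(=O)NCC(N)=O)[nH]c3ccc(Cl)cc23)c1`: > 100 uM (a limit)
Compound 2 `CNNC(=O)c1[nH]c2ccc(Cl)cc2c1S(=O)(=O)c1cc(C)cc(C)c1`: > 100 uM (a limit)

Compound 2 gives only a limit, not a number. Compound 3 `Cc1cc(C)cc(S(=O)(=O)c2c(C(=O)NNC(C)C)[nH]c3ccc(Cl)cc23)c1` differs from it in one group: isopropyl in place of methyl on an amine nitrogen. Going by the values given here, the only measured step, a step that the two limits leave unreadable from compound 1 to compound 2, changes a different group and gives no size to carry over. Among the compounds with values here, the only other evidence is the limit of > 100 uM in this assay, at which 2 of the 2 values shown sit, so compound 3 is expected to stay in the same low-toxicity range in this assay, with no clear shift in either direction. The expected change is a step that the limit leaves unreadable from compound 2 to compound 3. For compound 3 the estimate is 130 uM, with an expected range of 50 uM to 250 uM.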

Compound 3, half-maximal toxic concentration: > 100 uM
Compound 3: no number, only a limit (the forecaster's own chance of this, stated with the estimate: 80%); the middle value does not contradict the limit.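

In this assay compound 3 gives > 100 uM, which is a limit and not a number. Its steps from compound 1 and compound 2 therefore cannot be read. The compounds shown leave open whether changing these groups alters toxicity in this assay at all.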